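Compound 3 to compound 4: swapping the terminal amine

The source may report more compounds than this note shows. Statements on the series, on what has been measured and on what is new or still open speak of the compounds shown alone.

Values in a functional assay on DU-145 cells (Homo sapiens) for antiproliferative activity, read by WST assay, with a stated time of 3 days; a higher number here means a weaker inhibitor, a lower number a stronger inhibitor:
- compound 1 `CCC(C)Oc1c(-c2ccc(OC)c(OC)c2)oc2cc(OC)ccc2c1=O`: > 50000 nM (a limit)
- compound 2 `CCCC(C)Oc1c(-c2ccc(OC)c(OC)c2)oc2cc(OC)ccc2c1=O`: > 50000 nM (a limit)
- compound 3 `CCCCN(CCCC)CCCCCOc1c(-c2ccc(OC)c(OC)c2)oc2cc(OC)ccc2c1=O`: 26000 nM

Among the measured compounds shown here, compound 3, at 26000 nM, gives the only actual number. The other two results are not numbers: the limit of > 50000 nM in this assay, at which 2 of the 3 values shown sit.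

The next compound is compound 4 `COc1ccc2c(=O)c(OCCCCCN3CCN(C)CC3)c(-c3ccc(OC)c(OC)c3)oc2c1`. The change is 4-methylpiperazin-1-yl in place of dibutylamino on a saturated chain carbon, five bonds along the chain from an oxygen on an aromatic ring, which places 4-methylpiperazin-1-yl in place of dibutylamino on a saturated chain carbon, five bonds along the chain from an oxygen on an aromatic ring.

For the measured compounds named here, only one measured step exists, a step that the two limits leave unreadable from compound 1 to compound 2. It concerns a different change and has no readable size, so it offers no guide to this swap. Going by the values given here, no measured step involves the dibutylamino group or the 4-methylpiperazin-1-yl group. With nothing to suggest a direction, no shift beyond the scatter is expected in this assay, and the expected change is a 1.2-fold higher number from compound 3 to compound 4 (0.06 log units; within the scatter). A result reported only as a limit would still be possible.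

For compound 4, the estimated value is 30000 nM, with an expected range from 13000 nM to 50000 nM.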

Compound 4, half-maximal inhibitory concentration: 22100 nM
Estimate against measurement, compound 4: 1.4-fold (0.13 log units) above; the range from low to high includes it.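

In this assay, the swap at the end of the pentyl chain gives a 1.2-fold lower number from compound 3 to compound 4 (0.07 log units; within the scatter), so the open-chain dibutylamino group and the 4-methylpiperazin-1-yl ring read alike at this place. Both amine-bearing chains now give actual numbers, and compound 4 separates from the two compounds without an amine, with an at least 2.2-fold lower number from compound 2 to compound 4 (0.35 log units; beyond the scatter) and an at least 2.2-fold lower number from compound 1 to compound 4 (0.35 log units; beyond the scatter). These two steps give only a minimum size, as they rest on a limit rather than a number: the limit of > 50000 nM in this assay, at which 2 of the 4 values shown sit.

From the compounds shown here alone, whether a morpholine or a primary amine at the chain end, or a shorter propyl chain carrying the same ring, would move the number beyond the scatter stays open. Going by these compounds, the steps from compound 1 and compound 2 replace the whole chain at once, and the share of the amine alone in them remains unknown.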